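Replacing an oxime ether arm with a small carbamate

The source may hold more compounds than are shown below. What is called first, only, known or untested is meant among the compounds shown, and "the series" means these compounds.

Measured so far:
- compound 1, `CCOC(=O)c1csc(CO/N=C(\C)c2ccc(Sc3cc(F)cc(C4CCOCC4)c3)cc2)n1`: 150 nM
- compound 2, `C/C(=N\O)c1cccc(Sc2cc(F)cc(C3CCOCC3)c2)c1`: 2910 nM

Of the compounds shown here, two have been tested in a functional assay (blood) for inhibition, with Homo sapiens as the target; on this read-out higher numbers stand for weaker inhibition and lower numbers for stronger inhibition. Compound 1 gives 150 nM in this assay, the lower of the two numbers. Compound 2 gives 2910 nM in this assay, a weaker result that lies well beyond the usual scatter; the two structures differ in more than one place, so their pair says nothing about any single change.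

Compound 3, `C/C(=N\OC(=O)N(C)C)c1ccc(Sc2cc(F)cc(C3CCOCC3)c2)cc1`, has not yet been measured in this assay. Compared with compound 1 it carries dimethylcarbamoyl in place of (4-(ethoxycarbonyl)-1,3-thiazol-2-yl)methyl on an oxygen. Among the compounds with values here, the large arm is thus traded for a short one, and no measured pair shows what that exchange does here. Within the data shown here, since the only other measured compound, compound 2, lacks that arm and gives 2910 nM, the step from compound 1 to compound 3 is expected to go towards weaker inhibition, by an amount beyond the scatter, a 4.0-fold higher number from compound 1 to compound 3 (0.60 log units; beyond the scatter). Compound 3 is therefore estimated at 600 nM in this assay, within a range from 150 nM to 3000 nM.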

Compound 3, half-maximal inhibitory concentration: 2610 nM
The estimate for compound 3 lay 4.4-fold (0.64 log units) below the measured number; the measured number falls inside the stated range.
By their numbers in this assay, from the lowest: compound 1; then compounds 3 and 2 (each within the scatter of the next).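

In this assay, putting dimethylcarbamoyl in place of (4-(ethoxycarbonyl)-1,3-thiazol-2-yl)methyl on the oxygen bound to the double-bonded nitrogen gives a 17-fold higher number from compound 1 to compound 3 (1.24 log units; beyond the scatter) and is a large loss of inhibition. Within the data shown here, compound 1 and compound 3 differ in this one place only, so this is the first comparison that can be read as a single change, and it shows that inhibition in this assay responds strongly to what sits on this oxygen. The arm that leaves has 11 heavy atoms, one five-membered aromatic ring and 4 hydrogen-bond acceptors, whereas dimethylcarbamoyl has 5 heavy atoms, no ring and 1 hydrogen-bond acceptor, so all of these features change together in one step.

As far as these compounds go, it remains open which of these differences matters, for instance whether a carboxylic acid in place of the ethoxycarbonyl group, or a plain benzyl group on the same oxygen, would keep the lower number of compound 1. Nothing measured here explains the size of the step.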